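A few compounds are considered here, and "the series" means these few. Any claim that something is new, unique, unknown or untested is made for them only; others in the source may bear on it.

In an ADME assay on HEK293 cells (Homo sapiens) for cytotoxicity, read by fluorescence and resazurin assay, with a stated time of 24 h (a higher number here means that more compound is tolerated, a lower number that less compound is tolerated), compound 1 `O=S1(=O)C=C(Sc2nnc(-c3cccnc3)o2)c2ccccc21` gives 4000 nM, compound 2 `Nc1ccc(-c2nnc(SC3=CS(=O)(=O)c4ccccc43)o2)cc1` gives 4000 nM, and compound 3 `COc1cccc(-c2nnc(SC3=CS(=O)(=O)c4ccccc43)o2)c1` gives 3000 nM. Compound 3 therefore cannot be told apart from either of the other two, as all three values lie within the scatter of one another.

Compound 4 `O=S1(=O)C=C(Sc2nnc(-c3ccc(Cl)cc3)o2)c2ccccc21` has 4-chlorophenyl in place of the 3-methoxyphenyl of compound 3, on the same aromatic carbon of the five-membered aromatic ring with 2 nitrogen and 1 oxygen (4-chlorophenyl in place of 3-methoxyphenyl on an aromatic carbon). For the measured compounds named here, three measured steps bear on this change, since each swaps the group at this same place: no change at the digits printed from compound 1 to compound 2 (within the scatter), a 1.3-fold lower number from compound 1 to compound 3 (0.12 log units; within the scatter) and a 1.3-fold lower number from compound 2 to compound 3 (0.12 log units; within the scatter). All three stay within the scatter. Going by the values given here, none of the measured compounds carries chlorine, so the evidence for the entering group is only indirect. No change beyond the scatter is therefore expected in this assay.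

The expected step is no change at the digits printed from compound 3 to compound 4 (within the scatter). Compound 4 is estimated at 3000 nM, with an expected range from 1300 nM to 7000 nM.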

Compound 4, half-maximal cytotoxic concentration: 3000 nM
Beside the measured number, compound 4's estimate shows no gap at the digits printed, within the range that was stated.
By their numbers in this assay, from the lowest: compounds 3, 4, 1 and 2 (each within the scatter of the next).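

In this assay, a group carrying chlorine at this aromatic carbon of the five-membered ring gives no change at the digits printed from compound 3 to compound 4 (within the scatter) in exchange for 3-methoxyphenyl, so the earlier flat picture also holds for a halogen-bearing group. Measured against the other two groups, the change gives a 1.3-fold lower number from compound 2 to compound 4 (0.12 log units; within the scatter) and a 1.3-fold lower number from compound 1 to compound 4 (0.12 log units; within the scatter) as well, which leaves pyridin-3-yl, 4-aminophenyl, 3-methoxyphenyl and 4-chlorophenyl indistinguishable at this place. No supporting measurement accounts for this result.

As far as these compounds go, all four groups at this carbon are six-membered aromatic rings, so it remains open whether a carboxylic acid, a morpholine or a longer alkyl chain there would move this assay beyond the scatter. From the compounds shown here alone, the rest of the shared core is the same in all four compounds, so what a change elsewhere would do also remains open.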